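A few compounds are considered here, and "the series" means these few. Any claim that something is new, unique, unknown or untested is made for them only; others in the source may bear on it.

Measured so far:

- compound 1 `CCC1(Cc2ccccc2)OS(=O)(=O)C=C1OCc1ccccc1`: 200000 nM
- compound 2 `CCC1(Cc2ccccc2)OS(=O)(=O)C=C1OCc1ccc(C)cc1`: 41500 nM
- compound 3 `CCC1(Cc2ccccc2)OS(=O)(=O)C=C1OCc1ccccc1Cl`: 38000 nM

In an ADME assay on HEL cells (Homo sapiens) for cytotoxicity, with a stated time of 3 days (a lower number here means that less compound is tolerated, a higher number that more compound is tolerated), compound 1 gives the highest number of the three, so more of it is tolerated than of compound 2 or compound 3. The two changes made to compound 1 so far both sit on the aromatic ring of the benzyloxy group: a 4.8-fold lower number from compound 1 to compound 2 (0.68 log units; beyond the scatter) and a 5.3-fold lower number from compound 1 to compound 3 (0.72 log units; beyond the scatter), each a modest drop beyond the scatter. Compound 2 and compound 3 themselves stand close together, a 1.1-fold lower number from compound 2 to compound 3 (0.04 log units; within the scatter).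

Going by the values given here, compound 4 `CCC1(Cc2ccccc2)OS(=O)(=O)C=C1NCc1ccccc1` takes a different route. benzylamino in place of benzyloxy on a double-bonded ring carbon None of the measured steps exchanges the linking atom of this group for another, so no step bears directly on it; the only guide is that every change to this group so far has lowered the number by a modest amount. A step of that order or smaller is therefore expected in this assay, most likely downward, with a real chance that it stays within the scatter: a 2.0-fold lower number from compound 1 to compound 4 (0.30 log units; within the scatter). Compound 4 is estimated to give about 100000 nM, within a range of 35000 nM to 250000 nM.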

Compound 4, half-maximal cytotoxic concentration: 92000 nM
Beside the measured number, compound 4's estimate is 1.1-fold (0.04 log units) above it; measured number inside the range.
By their numbers in this assay, from the lowest: compounds 3 and 2 (each within the scatter of the next); then compound 4; then compound 1.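

In this assay the linking atom of this group on the double-bonded ring carbon turns out to count as well: benzylamino in place of benzyloxy gives a 2.2-fold lower number from compound 1 to compound 4 (0.34 log units; beyond the scatter) and so shows that the number responds to a change at the link, not only to changes on the aromatic ring. The swap keeps the aromatic ring and the heavy-atom total of the group and adds a hydrogen-bond donor, but a single pair cannot tie the drop to that donor. Nothing measured here explains the drop.

As far as these compounds go, it remains open whether a sulfur link, as in benzylthio, or a methylated nitrogen, as in N-methylbenzylamino, would give a number closer to that of compound 1 or further from it. From the compounds shown here alone, it is also open whether methyl or chloro on the aromatic ring of benzylamino would lower the number as they did on benzyloxy.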